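Moving from 2-chlorophenyl to 3-chlorophenyl

A few compounds are considered here, and "the series" means these few. Any claim that something is new, unique, unknown or untested is made for them only; others in the source may bear on it.

In a functional assay on MGC-803 cells (Homo sapiens) for cytotoxicity, read by MTT assay, with a stated time of 72 h (a higher number here means a weaker inhibitor, a lower number a stronger inhibitor), compound 1 `CC(=O)c1ccc(NC(=O)CSC(=S)N[C@H]2CCOC2=O)cc1` gives 99400 nM. Compound 2 `O=C(CSC(=S)N[C@H]1CCOC1=O)Nc1ccc(C(=O)/C=C/c2ccc(Br)cc2)cc1` gives 19600 nM. Within the data shown here, compound 3 `O=C(CSC(=S)N[C@H]1CCOC1=O)Nc1ccc(C(=O)/C=C/c2ccccc2Cl)cc1` gives 12400 nM, the lowest number so far, though it is not separated from compound 2: the step is a 1.6-fold lower number from compound 2 to compound 3 (0.20 log units; within the scatter).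

Compound 4 `O=C(CSC(=S)N[C@H]1CCOC1=O)Nc1ccc(C(=O)/C=C/c2cccc(Cl)c2)cc1` has 3-chlorophenyl in place of 2-chlorophenyl on a double-bonded chain carbon bound to a double-bonded chain carbon.

Among the measured compounds shown here, the nearest precedent is a 1.6-fold lower number from compound 2 to compound 3 (0.20 log units; within the scatter), which places 2-chlorophenyl where 4-bromophenyl stood. The larger steps, a 5.1-fold lower number from compound 1 to compound 2 (0.71 log units; beyond the scatter) and an 8.0-fold lower number from compound 1 to compound 3 (0.90 log units; beyond the scatter), replace methyl on a carbonyl carbon with a substituted ethenyl. For the measured compounds named here, compound 4 keeps such a group, as 2-(3-chlorophenyl)ethenyl, so these steps offer no precedent for a large change here. Going by the values given here, no measured pair compares 2-chlorophenyl directly with 3-chlorophenyl.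

No change beyond the scatter is therefore expected in this assay, and the expected step is a 1.1-fold higher number from compound 3 to compound 4 (0.05 log units; within the scatter). The estimate for compound 4 is 14000 nM, with an expected range of 6500 nM to 30000 nM.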

Compound 4, half-maximal inhibitory concentration: 15600 nM
Beside the measured number, compound 4's estimate is 1.1-fold (0.05 log units) below it; low and high end bracket the measured number.
By their numbers in this assay, from the lowest: compounds 3, 4 and 2 (each within the scatter of the next); then compound 1.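

Set against 2-chlorophenyl on a double-bonded chain carbon bound to a double-bonded chain carbon, 3-chlorophenyl gives the first direct comparison of these two groups in this assay (a 1.3-fold higher number from compound 3 to compound 4 (0.10 log units; within the scatter)), and the two are not separated. 3-Chlorophenyl is also not separated from 4-bromophenyl (a 1.3-fold lower number from compound 2 to compound 4 (0.10 log units; within the scatter)), while exchanging methyl for the ethenyl group bearing 3-chlorophenyl joins the other two substituted ethenyl groups in a step beyond the scatter (a 6.4-fold lower number from compound 1 to compound 4 (0.80 log units; beyond the scatter)), so all three aryl groups shown stand apart from methyl but not from each other. No measurement at hand accounts for this result.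

On these data alone, whether an aryl group carrying an amine or a carboxylic acid would stay level with these three remains open. Also open, as far as these compounds go, is what a longer chain in place of the ethenyl link would do to the number.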